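The source may hold more compounds than are shown below. What is called first, only, known or untested is meant among the compounds shown, and "the series" means these compounds.

List of measured compounds:
compound 1 `CCCCNc1nc(N)nc(C)c1CC` gives 1660 nM in an assay on HEK293 cells for agonist activity at Toll-like receptor 8 (Homo sapiens), read by spectrophotometry; a lower number here means that less compound is needed, a higher number that more compound is needed for the effect;
compound 2 `CCCCNc1nc(N)nc(C)c1CCc1ccccc1` gives 1190 nM in this assay;
compound 3 `CCCCNc1nc(N)nc(C)c1CCCC(C)(C)O` gives 1220 nM in this assay.

Compound 3 stands second highest of these three numbers, but all three lie within the scatter of one another. The step of a 1.4-fold lower number from compound 1 to compound 3 (0.13 log units; within the scatter) and the step of a 1.0-fold higher number from compound 2 to compound 3 (0.01 log units; within the scatter) both stayed within the scatter, as did a 1.4-fold lower number from compound 1 to compound 2 (0.14 log units; within the scatter). Compound 4 `CCCCNc1nc(N)nc(C)c1CCC(C)(C)O` differs from compound 3 in one place: 1-hydroxy-1-methylethyl in place of 2-hydroxy-2-methylpropyl on a saturated chain carbon, two bonds along the chain from an aromatic carbon. Within the data shown here, no measured step shortens this chain, and the steps that change the same place all stayed within the scatter, so no step beyond the scatter is expected in this assay. Compound 4 is therefore expected to give 1250 nM in this assay, within 500 nM to 3200 nM, an expected step of a 1.0-fold higher number from compound 3 to compound 4 (0.01 log units; within the scatter).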

Compound 4, half-maximal effective concentration: 3140 nM
The estimate for compound 4 lay 2.5-fold (0.40 log units) below the measured number; measured number inside the range.
By their numbers in this assay, from the lowest: compounds 2, 3, 1 and 4 (each within the scatter of the next, the first and the last beyond it).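

Swapping 2-hydroxy-2-methylpropyl for the smaller 1-hydroxy-1-methylethyl gives a 2.6-fold higher number from compound 3 to compound 4 (0.41 log units; beyond the scatter) in this assay and is the first change at this place to pass the scatter, though both groups have the same hydrogen-bond counts. The same group also separates from phenyl with a 2.6-fold higher number from compound 2 to compound 4 (0.42 log units; beyond the scatter) but not from hydrogen with a 1.9-fold higher number from compound 1 to compound 4 (0.28 log units; within the scatter), so only some comparisons at this place reveal a difference. No measurement here explains the step. On these data alone, whether a longer chain or an amine in place of the hydroxyl would shift the number remains open.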